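Tail flick notes: methyl in place of bromo

A few compounds are considered here, and "the series" means these few. Any claim that something is new, unique, unknown or untested is made for them only; others in the source may bear on it.

Measured so far:
compound 1, `CC(=O)N1N=C(c2ccc(F)cc2)CC1c1cn(-c2ccccc2)nc1-c1ccc(C)cc1`, 110%
compound 2, `Fc1ccc(C2=NN(c3ccccc3)C(c3cn(-c4ccccc4)nc3-c3ccc(Br)cc3)C2)cc1`, 71%

Two compounds have numbers in a functional assay on the whole organism (Tail) with Rattus norvegicus as the target, in the tail flick test, with a stated time of 60 min, at a dose of 25 mg/kg by the oral route; on this read-out lower numbers stand for less inhibition and higher numbers for more inhibition at the one dose given (going by the name of the read-out). Compound 1 gives 110%. Compound 2 gives 71%, the lower of the two, and the gap from compound 2 up to compound 1 lies beyond the scatter. Among the measured compounds shown here, these two differ at more than one place, so no single step between them is set out; the pair shows only that the methyl-bearing compound 1 stands higher.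

Compound 3, `Cc1ccc(-c2nn(-c3ccccc3)cc2C2CC(c3ccc(F)cc3)=NN2c2ccccc2)cc1`, is not yet measured. It differs from compound 2 by methyl in place of bromo on an aromatic carbon, on an aromatic carbon of a six-membered aromatic ring of carbon only, para to a large group; the rest of the structure is kept. For the measured compounds named here, no measured step of this kind exists, so the expected direction rests only on compound 1, which carries the same methyl group and gives 110%. A rise in this assay is therefore expected, but a moderate one; compound 1 also differs from compound 3 elsewhere. The step is expected at a number 14 percentage points higher from compound 2 to compound 3 (beyond the scatter). Compound 3 is estimated at 85%, within 55% to 110%.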

Compound 3, a percentage reported as inhibition, in the whole organism at one dose (the size of the read-out at that dose, not a potency): 110%
The estimate for compound 3 lay 25 percentage points below the measured number; the measured number falls inside the stated range.
By their numbers in this assay, from the lowest: compound 2; then compounds 1 and 3 (each within the scatter of the next).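

In this assay the swap of 4-bromophenyl to 4-methylphenyl, on its own with the rest of the structure kept, gives a number 39 percentage points higher from compound 2 to compound 3 (beyond the scatter), so this position on the six-membered aromatic ring now has a single-place reading and the read-out responds to this change. With 4-methylphenyl held, the second single-place comparison gives no change at the digits printed from compound 1 to compound 3 (within the scatter), so phenyl and acetyl on the amine nitrogen in the ring are not told apart on this background, and the change at that nitrogen does not show up in the read-out the way the change from bromo to methyl does. The data shown offer no measured basis for a cause of either result.

As far as these compounds go, it remains open whether other groups at this position, such as chloro, methoxy or a longer chain like ethyl, would read with compound 2 or with compound 3, and whether phenyl and acetyl on the ring nitrogen would also stay together with 4-bromophenyl in place. All of these readings come from one dose and one time point, so they give the size of the effect under those conditions and not a potency.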